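Enlarging the Sulfonyl Substituent on the Ring Nitrogen

A few compounds are considered here, and "the series" means these few. Any claim that something is new, unique, unknown or untested is made for them only; others in the source may bear on it.

Compound 3 `CN1CCN(c2ccc(C3=NN(S(C)(=O)=O)C(c4ccc(N(C)C)cc4)C3)cc2)CC1` is the lowest of the three measured compounds in a functional assay on HCC1806 cells (Homo sapiens) for inhibition, read by sulforhodamine B assay, tested at 10 uM (a lower number here means less inhibition, a higher number more inhibition at the concentration tested (going by the name of the read-out)), giving -18.5%. Its nearest neighbour is compound 1 `CN1CCN(c2ccc(C3=NN(C(=O)c4ccc(F)cc4)C(c4ccc(N(C)C)cc4)C3)cc2)CC1`, which gives 31.8%, and the furthest is compound 2 `CN1CCN(c2ccc(C3=NN(C(=O)/C=C/c4ccccc4)C(c4ccc(N(C)C)cc4)C3)cc2)CC1`, which gives 71%. The change from compound 3 to compound 4 `CN1CCN(c2ccc(C3=NN(S(=O)(=O)c4ccc(OC(F)(F)F)cc4)C(c4ccc(N(C)C)cc4)C3)cc2)CC1` is 4-(trifluoromethoxy)phenyl in place of methyl on a sulfonyl sulfur. Among the measured compounds shown here, no measured step tests an aryl against methyl on a sulfonyl sulfur; the steps that touch the ring nitrogen are a number 50.3 percentage points lower from compound 1 to compound 3 (beyond the scatter) and a number 89.5 percentage points lower from compound 2 to compound 3 (beyond the scatter), both placing the methylsulfonyl compound far below the acyl compounds. With only that to go on, a modest rise is expected for compound 4, a number 30.5 percentage points higher from compound 3 to compound 4 (beyond the scatter). Compound 4 is estimated at 12%, within -15% to 45%.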

Compound 4, a percentage reported as inhibition, at one concentration (the size of the read-out at that concentration, not a potency): 70.8%
Compound 4: middle estimate off by 58.8 percentage points, on the low side; the measured number lies above the stated range.
By their numbers in this assay, from the lowest: compound 3; then compound 1; then compounds 4 and 2 (each within the scatter of the next).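

In this assay the sulfonyl link on the ring nitrogen does not by itself hold the number down: 4-(trifluoromethoxy)phenyl in place of methyl on the sulfonyl sulfur gives a number 89.3 percentage points higher from compound 3 to compound 4 (beyond the scatter). Sulfonyl compound 4 at 70.8% and acyl compound 2 at 71% lie within the scatter of each other. Nothing measured here accounts for this step. Going by these compounds, whether the step comes from the aromatic ring or from its trifluoromethoxy group stays open. A plain phenyl or a 4-aminophenyl on the sulfonyl sulfur would separate the two.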